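A methyl-to-ethyl step in an antiproliferative series

A few compounds are considered here, and "the series" means these few. Any claim that something is new, unique, unknown or untested is made for them only; others in the source may bear on it.

Measured in a functional assay on MDA-MB-231 cells (Homo sapiens) for antiproliferative activity, with a stated time of 4 days; a lower number here means a stronger inhibitor, a higher number a weaker inhibitor:
Compound 1 `COc1ccc(-c2[nH]c3ccccc3c2C=O)cc1`: 470 nM
Compound 2 `CCCCc1ccc2[nH]c(-c3ccc(OC)cc3)c(C=C(C#N)C#N)c2c1`: 26 nM
Compound 3 `CCCCc1ccc2[nH]c(-c3ccc(C)cc3)c(C=C(C#N)C#N)c2c1`: 65 nM

Of the three values in this assay, compound 3 has the second highest number. At 65 nM, compound 3 lies above compound 2 and below compound 1, and both gaps are beyond the scatter.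

The next compound is compound 4 `CCCCc1ccc2[nH]c(-c3ccc(CC)cc3)c(C=C(C#N)C#N)c2c1`, which differs from compound 3 in one place: methyl in place of hydrogen on a saturated chain carbon bound to an aromatic carbon. This is methyl in place of hydrogen on a saturated chain carbon bound to an aromatic carbon, so that methyl becomes ethyl and 4-methylphenyl becomes 4-ethylphenyl.

Among the compounds with values here, only one measured step bears on this change, and it is a different exchange at the same group: a 2.5-fold higher number from compound 2 to compound 3 (0.40 log units; beyond the scatter), with methyl in place of methoxy on an aromatic carbon. Within the data shown here, no measured pair shows what ethyl does in place of methyl, so the direction remains open. Among the measured compounds shown here, with that modest step as the only guide, a step no larger is expected in this assay, most likely none beyond the scatter.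

The estimate amounts to an expected 1.1-fold lower number from compound 3 to compound 4 (0.03 log units; within the scatter).

For compound 4 the estimated value is 60 nM, with an expected range from 25 nM to 140 nM.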

Compound 4, half-maximal inhibitory concentration: 76 nM
Compound 4: the middle estimate sits 1.3-fold (0.10 log units) below what was measured, within the range that was stated.
By their numbers in this assay, from the lowest: compound 2; then compounds 3 and 4 (each within the scatter of the next); then compound 1.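

In this assay, within the data shown here, a 1.2-fold higher number from compound 3 to compound 4 (0.07 log units; within the scatter) gives the first direct reading of a change in the alkyl group itself, and it shows that extending methyl to ethyl, which adds 1 carbon, leaves the number within the scatter. Among these compounds, the 4-methylphenyl and 4-ethylphenyl compounds therefore cannot be told apart here, whereas the earlier compounds showed only an exchange of methoxy for methyl. With a 2.9-fold higher number from compound 2 to compound 4 (0.47 log units; beyond the scatter), ethyl in place of methoxy gives a modest step beyond the scatter, so methoxy keeps the lower number against both of the alkyl groups shown, and no information on the compounds explains either result.

Whether this tolerance continues is left open, as one added carbon says nothing about a longer chain such as n-propyl or n-butyl, or a branched group such as isopropyl. It is also unresolved whether the difference from methoxy depends on that group's oxygen, a question that ethoxy or hydroxyl at this place could address, while an amine or a carboxylic acid there remains unexplored in the compounds shown.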